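The source may report more compounds than this note shows. Statements on the series, on what has been measured and on what is new or still open speak of the compounds shown alone.

Measured so far in a functional assay on HL-60 cells (Homo sapiens) for inhibition, read by CCK-8 assay, with a stated time of 48 h; a higher number here means a weaker inhibitor, a lower number a stronger inhibitor:

Compound 1 `O=[N+]([O-])c1ccc(NC(=S)NCCNS(=O)(=O)c2ccc(-c3ccccc3OCc3ccccc3)s2)cc1` gives only a limit, > 50000 nM.
Compound 2 `O=[N+]([O-])c1cccc(NC(=S)NCCNS(=O)(=O)c2ccc(-c3ccccc3OCc3ccccc3)s2)c1` gives only a limit, > 50000 nM.
Compound 3 `COc1ccc(Oc2ccccc2-c2ccsc2S(=O)(=O)N2CCN(C(=O)Nc3cccc([N+](=O)[O-])c3)CC2)cc1OC` gives only a limit, > 50000 nM.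

All three values sit at the limit of > 50000 nM in this assay, at which 3 of the 3 values shown sit, so nothing within the series is resolved in this assay. The change from compound 2 to compound 1 is 4-nitrophenyl in place of 3-nitrophenyl on an amide-type nitrogen and its step, a step that the two limits leave unreadable from compound 2 to compound 1, cannot be read because both ends are limits. The difference between the core of compound 2 and the core of compound 3 is not broken down here.

Compound 4 `COc1ccc(Oc2ccccc2-c2ccsc2S(=O)(=O)N2CCN(C(=O)Nc3ccc([N+](=O)[O-])cc3)CC2)cc1OC` is the still unmeasured partner of compound 3. The change from compound 3 to compound 4 is 4-nitrophenyl in place of 3-nitrophenyl on an amide-type nitrogen. The place lines differ: in compound 2 the amide-type nitrogen also carries a thiocarbonyl carbon, in compound 3 a carbonyl carbon, so this is the same kind of change, not the same change.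

The step from compound 3 to compound 4 is expected to be a step that the limit leaves unreadable from compound 3 to compound 4, which rests on the fact that compound 3 sits at a limit, > 50000 nM, and on compound 2 and compound 1 both sitting at limits. Compound 4 is therefore estimated at 70000 nM, with a range of 20000 nM to 300000 nM, and most likely this assay reports again only a limit.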

Compound 4, half-maximal inhibitory concentration: > 50000 nM
Compound 4 ended at the assay's limit (the forecaster's own chance of this, stated with the estimate: 85%); the middle value is on the limit's open side.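

No step can be read from compound 3 to compound 4 in this assay, because both ends are limits: the limit of > 50000 nM in this assay, at which 4 of the 4 values shown sit.

The compounds shown leave open whether 4-nitrophenyl in place of 3-nitrophenyl on an amide-type nitrogen changes inhibition in this assay, and whether either core can give a value inside the assay's range.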